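Methoxy Added to the Compound of a Pair With the Higher Number

The source may hold more compounds than are shown below. What is called first, only, known or untested is meant among the compounds shown, and "the series" means these compounds.

Compound 2, `CCC(=O)Nc1cccc(Oc2nc(Nc3ccc(N4CCCCC4)cc3)ncc2Cl)c1`, stands highest of the two numbers in an assay on isolated protein for inhibition of NUAK family SNF1-like kinase 1 (Homo sapiens), read by ADP-Glo, with a stated time of 60 min, tested at 10 uM, in the presence of a further agent that is not named here (a higher number here means more inhibition at the concentration tested (going by the name of the read-out), a lower number less inhibition), where compound 2 gives 86%. Its nearest neighbour, compound 1, `CCC(=O)Nc1cccc(Oc2nc(Nc3ccc(N4CCCC4)cc3OC)ncc2Cl)c1`, gives 25.8% in this assay, a gap beyond the usual scatter; the two structures differ in more than one place, so their values are simply set side by side. Compound 3, `CCC(=O)Nc1cccc(Oc2nc(Nc3ccc(N4CCCCC4)cc3OC)ncc2Cl)c1`, is not yet measured in this assay. It differs from compound 2 by methoxy in place of hydrogen on an aromatic carbon. Among the compounds with values here, no measured pair shows this change alone, so its direction rests on the surrounding numbers only. Compound 1, which also carries a methoxy group, gives 25.8%, far below compound 2, and the same group enters in compound 3, so a fall beyond the scatter is expected for the step of a number 36 percentage points lower from compound 2 to compound 3 (beyond the scatter). Compound 3 is therefore estimated at 50%, with a range from 20% to 80%.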

Compound 3, a percentage reported as inhibition, at one concentration (the size of the read-out at that concentration, not a potency): 13.9%
Compound 3: the middle estimate sits 36.1 percentage points above what was measured; measured number outside the range, below it.
By their numbers in this assay, from the lowest: compound 3; then compound 1; then compound 2.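

In this assay, the change of methoxy in place of hydrogen, on an aromatic carbon ortho to a large group and meta to a piperidin-1-yl group, can now be read alone, and it gives a number 72.1 percentage points lower from compound 2 to compound 3 (beyond the scatter). With the methoxy group held in place, piperidin-1-yl in place of pyrrolidin-1-yl gives a number 11.9 percentage points lower from compound 1 to compound 3 (beyond the scatter), so of the two single changes shown, the methoxy step is the large one and the ring change the modest one. Nothing given here explains either step.

The compounds shown leave open whether fluoro, methyl or hydroxy at this position would keep the number of compound 2 or lower it as methoxy does. They also leave open whether the step from pyrrolidin-1-yl to piperidin-1-yl would run the same way without the methoxy group.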